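A few compounds are considered here, and "the series" means these few. Any claim that something is new, unique, unknown or untested is made for them only; others in the source may bear on it.

Measured compounds:
Compound 1, `NC(=O)c1cccc(CN(CCCCC(=O)O)C[C@H]2O[C@@H](n3cnc4c(N)ncnc43)[C@H](O)[C@@H]2O)c1`: in an assay on cells for inhibition of Nicotinamide N-methyltransferase (Homo sapiens), with stated times of 10 min and 30 min (on this read-out lower numbers stand for stronger inhibition and higher numbers for weaker inhibition), compound 1 gives > 250000 nM, which is a limit of the assay rather than a number.
Compound 2, `COC(=O)c1cccc(CN(CCCC(N)=O)C[C@H]2O[C@@H](n3cnc4c(N)ncnc43)[C@H](O)[C@@H]2O)c1`: in this assay compound 2 gives > 250000 nM, again a limit and not a number.

Among the compounds with values here, compound 2 therefore stands at the edge of what this assay can report; no number places it, and the only other value shown sits at the same edge, as the limit of > 250000 nM in this assay, at which 2 of the 2 values shown sit, states. Compound 3, `COC(=O)c1cccc(CN(CCCCC(=O)O)C[C@H]2O[C@@H](n3cnc4c(N)ncnc43)[C@H](O)[C@@H]2O)c1`, has not yet been measured. It differs from compound 2 in one place: carboxymethyl in place of carbamoyl on a saturated chain carbon, three bonds along the chain from an amine nitrogen. Compound 3 thus carries the methyl ester of compound 2 together with the acid chain of compound 1, and both of those compounds reach only the limit.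

Within the data shown here, with no measured step to lean on, the expectation for the move from compound 2 to compound 3 is no shift beyond the usual scatter, an estimated step that the limit leaves unreadable from compound 2 to compound 3. Compound 3 is accordingly expected to give about 300000 nM, within a range from 100000 nM to 1000000 nM, most likely reported once more only as a limit.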

Compound 3, half-maximal inhibitory concentration: > 250000 nM
Compound 3: no number, only a limit (the forecaster's own chance of this, stated with the estimate: 85%); the middle value lies beyond the limit too.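

In this assay compound 3 gives > 250000 nM, a limit and not a number. No size can be read for its step from compound 2 or from compound 1, as all three compounds share one edge: the limit of > 250000 nM in this assay, at which 3 of the 3 values shown sit. The compounds shown leave open how strongly each inhibits the enzyme and whether these changes matter.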